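Replacing the nitro group of compound 2

The source may hold more compounds than are shown below. What is called first, only, known or untested is meant among the compounds shown, and "the series" means these compounds.

In an ADME assay on MT2 cells (Homo sapiens) for cytotoxicity, read by XTT assay, with a stated time of 4 days (on this read-out higher numbers stand for lower toxicity in this test and lower numbers for higher toxicity in this test), compound 1 (`Cc1cc(/C=C/C(=O)O)cc(C)c1Oc1ccc([N+](=O)[O-])c(Nc2ccc(C#N)cc2)n1`) gives 34800 nM. Compound 2 (`Cc1cc(/C=C/C#N)cc(C)c1Oc1ccc([N+](=O)[O-])c(Nc2ccc(C#N)cc2)n1`) reads > 100000 nM, which is a limit of the assay. Compound 3 (`CC(=O)/C=C/c1cc(C)c(Oc2cc(Nc3ccc(C#N)cc3)c([N+](=O)[O-])cc2[N+](=O)[O-])c(C)c1`) reads > 100000 nM, also a limit. Compound 2 thus stands at the limit of > 100000 nM in this assay, at which 2 of the 3 values shown sit, with no number of its own.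

Compound 4 (`Cc1cc(/C=C/C#N)cc(C)c1Oc1ccc(N)c(Nc2ccc(C#N)cc2)n1`) carries one change from compound 2: amino in place of nitro on an aromatic carbon, ortho to a (4-cyanophenyl)amino group.

Within the data shown here, the only measured step is an at least 2.8-fold higher number from compound 1 to compound 2 (0.45 log units; beyond the scatter). It lies on the chain and not at this place, so it offers a rough size and no direction. Since compound 2 offers only a limit, any number for compound 4 in this assay would have to fall lower, and a second limit remains possible. The expected move is an at least 2.5-fold lower number from compound 2 to compound 4 (0.39 log units; beyond the scatter), a modest step toward lower numbers. For compound 4 the estimate is 40000 nM, with an expected range of 10000 nM to 100000 nM.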

Compound 4, half-maximal cytotoxic concentration: 5630 nM
Beside the measured number, compound 4's estimate is 7.1-fold (0.85 log units) above it, outside the stated range (below it).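

In this assay, the aromatic carbon ortho to a (4-cyanophenyl)amino group proves sensitive to its substituent: amino in place of nitro gives an at least 17-fold lower number from compound 2 to compound 4 (1.24 log units; beyond the scatter). Among these compounds, this change runs toward higher toxicity in this test, the opposite direction to the one step on the chain, an at least 2.8-fold higher number from compound 1 to compound 2 (0.45 log units; beyond the scatter), and it shows that the shared core with the cyanovinyl chain can give a measured number rather than a limit. The size of the new step remains a lower bound, as the value for compound 2 is a limit of the assay: the limit of > 100000 nM in this assay, at which 2 of the 4 values shown sit.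

Only nitro and amino are shown at this place, so it remains open whether the shift follows from the loss of nitro or from the presence of amino. Hydrogen, a methyl group or an acetamido group on this carbon would help to separate the two readings.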